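Adding chloro to the phenoxy group of compound 2

The compounds below may be only part of what the source reports. "The series", "measured", "known", "first", "only" and "open" are said of these compounds alone.

Of the compounds shown here, two have been measured so far in a functional assay on A549 cells (Homo sapiens) for antiproliferative activity, read by MTT assay, with a stated time of 48 h (on this read-out lower numbers stand for stronger inhibition and higher numbers for weaker inhibition), and they lie far apart. Compound 1 `COc1ccc(Oc2nc3ccccc3cc2/C=N/NC(=O)Cn2c([N+](=O)[O-])cnc2C)cc1` gives 920 nM there, while compound 2 `Cc1ccc2nc(Oc3ccccc3)c(/C=N/NC(=O)Cn3c([N+](=O)[O-])cnc3C)cc2c1` gives 7180 nM and so holds the higher of the two numbers, by a gap beyond the usual scatter. These two differ in more than one place, so no single change can be read from them. Compound 3 `Cc1ccc2nc(Oc3ccc(Cl)cc3)c(/C=N/NC(=O)Cn3c([N+](=O)[O-])cnc3C)cc2c1` keeps compound 2 but has chloro in place of hydrogen on an aromatic carbon, para to a large group, turning phenoxy into 4-chlorophenoxy (chloro in place of hydrogen on an aromatic carbon). Within the data shown here, no measured pair shows this change alone, so only a small shift is expected. In this assay the estimated step is a 2.1-fold lower number from compound 2 to compound 3 (0.31 log units; beyond the scatter) toward stronger inhibition, close to the scatter in size. Compound 3 is expected at 3500 nM with an estimated range of 1000 nM to 11000 nM on this read-out.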

Compound 3, half-maximal inhibitory concentration: 1230 nM
Compound 3: middle estimate off by 2.8-fold (0.45 log units), on the high side, within the range that was stated.
By their numbers in this assay, from the lowest: compounds 1 and 3 (each within the scatter of the next); then compound 2.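

Among these compounds, compound 2 and compound 3 form the first pair here that differs in one place only, so a single change can now be read on its own. In this assay, turning phenoxy into 4-chlorophenoxy gives a 5.8-fold lower number from compound 2 to compound 3 (0.77 log units; beyond the scatter), toward stronger inhibition. This shows that the position is sensitive to substitution, since one added chlorine atom on the aromatic ring moves the number by more than the usual scatter, although nothing available here bears on why.

As far as these compounds go, whether this step belongs to chloro itself remains open, and fluoro or an amine at the same place would help to settle that. From the compounds shown here alone, it is also open whether the same change would give a similar step on a different core.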